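A few compounds are considered here, and "the series" means these few. Any claim that something is new, unique, unknown or untested is made for them only; others in the source may bear on it.

In a functional assay on HepG2 cells (Homo sapiens) for inhibition, read by MTT assay, with a stated time of 72 h (on this read-out higher numbers stand for weaker inhibition and lower numbers for stronger inhibition), compound 2 `N#Cc1ccc(-n2cc(COc3cccc(NC(=O)Nc4ccc(Cl)c(C(F)(F)F)c4)c3)nn2)cc1` gives 2980 nM. Compound 1 `O=C(Nc1cccc(OCc2cn(-c3ccccc3)nn2)c1)Nc1ccc(Cl)c(C(F)(F)F)c1` gives 1780 nM and compound 3 `O=C(Nc1cccc(OCc2cn(-c3ccc(Cl)cc3)nn2)c1)Nc1ccc(Cl)c(C(F)(F)F)c1` gives 2490 nM; the gaps from compound 2 to both, a 1.7-fold higher number from compound 1 to compound 2 (0.22 log units; within the scatter) and a 1.2-fold lower number from compound 2 to compound 3 (0.08 log units; within the scatter), lie within the scatter, so the three numbers cannot be told apart. Compound 4 `O=C(Nc1cccc(OCc2cn(-c3ccc(I)cc3)nn2)c1)Nc1ccc(Cl)c(C(F)(F)F)c1` differs from compound 2 by iodo in place of cyano on an aromatic carbon. The nearest measured step swaps a halogen for the cyano at the same place, a 1.2-fold lower number from compound 2 to compound 3 (0.08 log units; within the scatter), and the step of a 1.4-fold higher number from compound 1 to compound 3 (0.15 log units; within the scatter) at that place is also within the scatter. A step of the kind a 1.2-fold lower number from compound 2 to compound 4 (0.08 log units; within the scatter) is therefore expected, with no change beyond the scatter. Compound 4 is estimated to give 2500 nM, with a range from 1200 nM to 5500 nM.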

Compound 4, half-maximal inhibitory concentration: 2690 nM
Beside the measured number, compound 4's estimate is 1.1-fold (0.03 log units) below it; the range from low to high includes it.
By their numbers in this assay, from the lowest: compounds 1, 3, 4 and 2 (each within the scatter of the next).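

Iodo now joins chloro and cyano at this place on the aromatic ring, and the number does not shift readably: the steps are a 1.1-fold lower number from compound 2 to compound 4 (0.04 log units; within the scatter), a 1.1-fold higher number from compound 3 to compound 4 (0.03 log units; within the scatter) and a 1.5-fold higher number from compound 1 to compound 4 (0.18 log units; within the scatter). Even the step from hydrogen to iodo stays inside the scatter, so none of the four groups shown at this place can be told apart in this assay. No measurement here explains this result. From the compounds shown here alone, whether an amine, a carboxylic acid or a longer chain at this place would move the number beyond the scatter remains open.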